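From compound 3 to compound 4: notes on the step

This account rests on a few compounds, and the source may have more. Where it says the series, first, only, none or still open, it means among the compounds named here.

Values in a functional assay on A549 cells (Homo sapiens) for antiproliferative activity, read by MTT assay, with a stated time of 24 h; on this read-out lower numbers stand for stronger inhibition and higher numbers for weaker inhibition:
- compound 1 `Cc1cccc(NNC(=O)c2cccc(NS(=O)(=O)c3cnc(O)nc3O)c2)c1`: > 20000 nM (a limit)
- compound 2 `O=C(NNc1ccccc1F)c1cccc(NS(=O)(=O)c2cnc(O)nc2O)c1`: 11100 nM
- compound 3 `O=C(NNc1ccc(F)cc1)c1cccc(NS(=O)(=O)c2cnc(O)nc2O)c1`: > 20000 nM (a limit)

Compound 3 stands at > 20000 nM, which is a limit and not a number. This is the limit of > 20000 nM in this assay, at which 2 of the 3 values shown sit, so compound 3 has no exact position in the series. Among the measured compounds shown here, compound 2, at 11100 nM, holds the only exact value.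

Compound 4 `O=C(NNC(=O)c1ccccc1Cl)c1cccc(NS(=O)(=O)c2cnc(O)nc2O)c1`, not yet measured, carries (2-chlorophenyl)carbonyl in place of 4-fluorophenyl on an amine nitrogen.

The measured steps at this nitrogen are an at least 1.8-fold lower number from compound 1 to compound 2 (0.25 log units; that floor lies within the scatter), an at least 1.8-fold higher number from compound 2 to compound 3 (0.25 log units; that floor lies within the scatter) and a step that the two limits leave unreadable from compound 1 to compound 3. All three exchange one substituted phenyl for another, and none brings in a carbonyl, so they bear on this change only loosely. None of them is shown to exceed the scatter, so no step beyond the scatter is expected, in either direction. The expected change is an at least 1.1-fold lower number from compound 3 to compound 4 (0.04 log units; that floor lies within the scatter), and this estimate is uncertain since its starting point is a limit. A limit is about as likely as a number for compound 4 in this assay. For compound 4 the estimated value is 18000 nM, with an expected range from 8000 nM to 40000 nM.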

Compound 4, half-maximal inhibitory concentration: 3740 nM
Beside the measured number, compound 4's estimate is 4.8-fold (0.68 log units) above it, outside the stated range (below it).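

In this assay, among the compounds shown here, the amine nitrogen whose other neighbour is the amide-type nitrogen proves able to carry a group other than a substituted phenyl, and (2-chlorophenyl)carbonyl in place of 2-fluorophenyl gives a 3.0-fold lower number from compound 2 to compound 4 (0.47 log units; beyond the scatter), the only step at this nitrogen with exact values at both ends. Starting from the other two phenyl groups, the exchange reads as an at least 5.3-fold lower number from compound 3 to compound 4 (0.72 log units; beyond the scatter) and as an at least 5.3-fold lower number from compound 1 to compound 4 (0.72 log units; beyond the scatter), and each of these is a floor that already clears the scatter, unlike every earlier step at this nitrogen. Compound 1 and compound 3 each stand at a limit and not at a number, so the full size of these two steps stays unread: the limit of > 20000 nM in this assay, at which 2 of the 4 values shown sit.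

The change brings in the carbonyl and the chlorine together, so the compounds shown do not tell which of the two carries the lower number. A plain benzoyl group, a (4-chlorophenyl)carbonyl group or an acetyl group at the same nitrogen would separate the carbonyl from the chlorine and from the ring.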